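A few compounds are considered here, and "the series" means these few. Any claim that something is new, unique, unknown or untested is made for them only; others in the source may bear on it.

Working notes on the series. Compound 3 `COc1ccc(Cn2c(=O)nc(NCCNC(=N)N)n(Cc3ccc(Cl)c(Cl)c3)c2=O)cc1` gives 0.0045 nM in a functional assay on the whole organism (strain C57Bl/6) for inhibition, with Mus musculus as the target, with a stated time of 180 min, at 48 degrees C; on this read-out higher numbers stand for an effect only at larger amounts of compound and lower numbers for an effect already at smaller amounts. Compound 2 `COc1ccc(Cn2c(NCCNC(=N)N)nc(=O)n(Cc3ccc(C)cc3)c2=O)cc1` gives 0.0044 nM; compound 3 and compound 2 lie within the scatter of each other. Compound 1 `COc1ccc(Cn2c(=O)nc(NCCNC(=N)N)n(Cc3ccc(F)cc3)c2=O)cc1` gives 0.036 nM, and the step of an 8.0-fold lower number from compound 1 to compound 3 (0.90 log units; beyond the scatter) is the only measured one bearing on this position. Compound 4 `COc1ccc(Cn2c(NCCNC(=N)N)nc(=O)n(Cc3ccc(OC)cc3)c2=O)cc1` carries the change (4-methoxyphenyl in place of 3,4-dichlorophenyl on a saturated chain carbon bound to an aromatic nitrogen). Going by the values given here, no measured step covers this exact exchange; the neighbours show that the aryl group at this carbon matters, with compound 1 standing apart while compound 2 and compound 3 agree. Compound 4 is therefore expected to stay near the upper part of the range, with a step of about a 2.2-fold higher number from compound 3 to compound 4 (0.35 log units; beyond the scatter) toward a somewhat higher number. Compound 4 is estimated at 0.01 nM, between 0.003 nM and 0.04 nM.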

Compound 4, half-maximal effective concentration: 0.000053 nM
For compound 4 the middle estimate is 190-fold (2.28 log units) above the measured one; the measured number lies below the stated range.
By their numbers in this assay, from the lowest: compound 4; then compounds 2 and 3 (each within the scatter of the next); then compound 1.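

In this assay, 4-methoxyphenyl on a saturated chain carbon bound to an aromatic nitrogen stands well apart from the other aryl groups at this position (an 85-fold lower number from compound 3 to compound 4 (1.93 log units; beyond the scatter)) (an 83-fold lower number from compound 2 to compound 4 (1.92 log units; beyond the scatter)) (a 680-fold lower number from compound 1 to compound 4 (2.83 log units; beyond the scatter)). The agreement of compound 2 and compound 3 therefore marked no lower limit for this position, and methoxy differs sharply here from both methyl and fluoro. No evidence at hand accounts for this separation. Going by these compounds, it remains open whether ethoxy, hydroxy or dimethylamino in place of the methoxy would keep a number near that of compound 4.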